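A few compounds are considered here, and "the series" means these few. Any claim that something is new, unique, unknown or untested is made for them only; others in the source may bear on it.

Of the compounds shown here, two from this series have been tested. Compound 1 `COc1cc2c(cc1CC=C(C)C)/C(=N/NC(N)=O)C[C@@H](c1ccc(O)cc1)O2` carries a semicarbazone and a phenol on its core, and in a functional assay on PC-3 cells (Homo sapiens) for inhibition, read by sulforhodamine B assay, with a stated time of 48 h, tested at 50 uM (a lower number here means less inhibition of growth, a higher number more inhibition of growth at the concentration tested), compound 1 gives 67%. Compound 2 `COc1ccc([C@@H]2C/C(=N/OCc3cn(-c4ccc(Cl)cc4C)nn3)c3cc(CC=C(C)C)c(OC)cc3O2)cc1` instead bears an oxime ether linked through a triazole to a 4-chloro-2-methylphenyl group, and in this assay compound 2 gives 49%. Of the two numbers, compound 2 stands lowest, and the nearest value, that of compound 1, lies higher by a gap that is beyond the scatter of this assay. For the measured compounds named here, no pair of measured compounds differs in only one place, so no single structural step can yet be read from the numbers.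

Compound 3 `COc1ccc([C@@H]2C/C(=N/OCc3cn(-c4cccnc4Cl)nn3)c3cc(CC=C(C)C)c(OC)cc3O2)cc1` keeps the oxime ether and the triazole of compound 2 and differs in one place: 2-chloropyridin-3-yl in place of 4-chloro-2-methylphenyl on an aromatic nitrogen. One aromatic ring of carbon only is exchanged for one six-membered aromatic ring with 1 hetero atom, a swap that keeps the size of the group nearly the same. Going by the values given here, with no comparable step available, the step expected from compound 2 to compound 3 is small, a number 2 percentage points lower from compound 2 to compound 3 (within the scatter), and may well fall within the scatter in either direction. For compound 3 in this assay the estimate is 47%, with a range from 30% to 64%.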

Compound 3, percent growth inhibition at one concentration: 44%
Estimate against measurement, compound 3: 3 percentage points above; the measured number falls inside the stated range.
By their numbers in this assay, from the lowest: compounds 3 and 2 (each within the scatter of the next); then compound 1.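

In this assay, for the compounds shown here, putting 2-chloropyridin-3-yl in place of 4-chloro-2-methylphenyl on an aromatic nitrogen of the five-membered aromatic ring with 3 nitrogen gives a number 5 percentage points lower from compound 2 to compound 3 (within the scatter), and this is the first comparison in which only one place differs. At this position, then, one aromatic ring of carbon only can be exchanged for one six-membered aromatic ring with 1 hetero atom, gaining the hydrogen-bond acceptor counted on the entering group, without a change in growth inhibition that stands out from the scatter. Nothing measured on these compounds speaks to the reason for this outcome.

Going by these compounds, whether this position accepts groups of a different kind, such as a benzyl group, a simple alkyl chain or a phenyl ring carrying an amine or a carboxylic acid, remains open, since both groups compared here are chlorine-bearing six-membered aromatic rings. Compound 1 differs from compound 2 and compound 3 in more than one place, so the contributions of its semicarbazone and phenol cannot be read from any single step.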